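Replacing the acid side group of compound 3

The compounds below may be only part of what the source reports. "The series", "measured", "known", "first", "only" and "open" are said of these compounds alone.

Measured so far in a functional assay on HepG2 cells (Homo sapiens) for antiproliferative activity, read by CCK-8 assay, with a stated time of 48 h; a lower number here means a stronger inhibitor, a higher number a weaker inhibitor
Compound 1 `COc1ccc(/C=C\c2cc(OC)c(OC)c(OC)c2)cc1OCc1ccc(C=O)cc1` gives 800 nM
Compound 2 `COc1ccc(/C=C\c2cc(OC)c(OC)c(OC)c2)cc1OCc1ccc(CN2CCCCC2C(=O)NCCNC(=O)OC(C)(C)C)cc1` gives 1100 nM
Compound 3 `COc1ccc(/C=C\c2cc(OC)c(OC)c(OC)c2)cc1OCc1ccc(CN2CC[C@H](C(=O)O)C2)cc1` gives 6400 nM

Compound 3 has the highest number of the three, which makes it the weakest inhibitor in this set. Compound 4 `COc1ccc(/C=C\c2cc(OC)c(OC)c(OC)c2)cc1OCc1ccc(CN2CCCCC2C(=O)NCCN)cc1` has not yet been measured. Its change from compound 3 is 2-((2-aminoethyl)carbamoyl)piperidin-1-yl in place of 3-carboxypyrrolidin-1-yl on a saturated chain carbon bound to an aromatic carbon and amounts to 2-((2-aminoethyl)carbamoyl)piperidin-1-yl in place of 3-carboxypyrrolidin-1-yl on a saturated chain carbon bound to an aromatic carbon.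

Among the compounds with values here, one measured step bears directly on this: an 8.0-fold higher number from compound 1 to compound 3 (0.90 log units; beyond the scatter) when the carboxypyrrolidine group arrived, and compound 4 gives that group up. Within the data shown here, compound 2 at 1100 nM also carries the piperidine amide, but its chain is capped with a tert-butyl carbamate, so no measured compound shows the free amine. A step to a lower number is therefore expected in this assay, with its size uncertain. The estimated change is a 4.3-fold lower number from compound 3 to compound 4 (0.63 log units; beyond the scatter) as a moderate gain. For compound 4 the expected value is 1500 nM within an estimated range from 400 nM to 5000 nM in repeat measurements.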

Compound 4, half-maximal inhibitory concentration: 4800 nM
Compound 4: the middle estimate sits 3.2-fold (0.51 log units) below what was measured; measured number inside the range.
By their numbers in this assay, from the lowest: compounds 1 and 2 (each within the scatter of the next); then compounds 4 and 3 (each within the scatter of the next).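

In this assay, putting 2-((2-aminoethyl)carbamoyl)piperidin-1-yl in place of 3-carboxypyrrolidin-1-yl on this saturated chain carbon gives a 1.3-fold lower number from compound 3 to compound 4 (0.12 log units; within the scatter), so these two quite different groups cannot be told apart here. The end of the chain counts for more: hydrogen in place of tert-butoxycarbonyl on the amine nitrogen gives a 4.4-fold higher number from compound 2 to compound 4 (0.64 log units; beyond the scatter), a step beyond the scatter. No supporting data explain why the protected and free amines differ.

The step between compound 3 and compound 4 changes the ring and the side chain together, so a piperidine ring bearing a carboxylic acid would be needed to separate the two changes. On these data alone, it also remains open whether a small acetyl group on the amine nitrogen would act like the tert-butoxycarbonyl group or like hydrogen.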